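The source may report more compounds than this note shows. Statements on the series, on what has been measured and on what is new or still open speak of the compounds shown alone.

Three compounds that share one core were tested in an ADME assay on HEK293 cells (Homo sapiens) for cytotoxicity, with a stated time of 72 h; on this read-out lower numbers stand for an effect already at smaller amounts and higher numbers for an effect only at larger amounts of compound. Compound 1 `Cc1cc(NC(=O)Nc2ccc(N)cc2)c2ccccc2n1` gives > 25000 nM, which is a limit of the assay rather than a number. Compound 2 `CC(=O)c1ccc(NC(=O)Nc2cc(C)nc3ccccc23)cc1` gives > 25000 nM, again only a limit. Compound 3 `Cc1cc(NC(=O)Nc2ccc(Cl)cc2)c2ccccc2n1` gives > 25000 nM, also a limit. Because the limit of > 25000 nM in this assay, at which 3 of the 3 values shown sit, none of the steps between these three can be read: a step that the two limits leave unreadable from compound 1 to compound 2, a step that the two limits leave unreadable from compound 1 to compound 3 and a step that the two limits leave unreadable from compound 2 to compound 3 all stay hidden behind that limit. Compound 3 thus stands at the limit together with the other two, with no order among them.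

Compound 4 `Cc1cc(NC(=O)Nc2ccc(SC(F)(F)F)cc2)c2ccccc2n1` differs from compound 3 in one place: (trifluoromethyl)sulfanyl in place of chloro on an aromatic carbon. The three measured steps all change the group at this same place, yet none has a readable size, so they give neither a size nor a direction for this change. Compound 4 is expected to show a step that the limit leaves unreadable from compound 3 to compound 4 in this assay, which is estimated to stay within the scatter. Compound 4 is therefore estimated at 30000 nM, between 10000 nM and 100000 nM, and is most likely to be reported again only as a limit.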

Compound 4, half-maximal effective concentration: 13000 nM
Compound 4: middle estimate off by 2.3-fold (0.36 log units), on the high side, and the stated range covers the measured number.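

Compound 4 is the first of these compounds to give a number rather than a limit in this assay, which shows that a readable value can be reached with a change at this place, on an aromatic carbon para to a large group. Against the other three, the change reads as an at least 1.9-fold lower number from compound 3 to compound 4 (0.28 log units; that floor lies within the scatter) for (trifluoromethyl)sulfanyl in place of chloro, an at least 1.9-fold lower number from compound 2 to compound 4 (0.28 log units; that floor lies within the scatter) for the same group in place of acetyl and an at least 1.9-fold lower number from compound 1 to compound 4 (0.28 log units; that floor lies within the scatter) for it in place of amino. Each of these sizes is only a floor, since the other three compounds give no number: the limit of > 25000 nM in this assay, at which 3 of the 4 values shown sit.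

As far as these compounds go, whether compound 4 truly lies lower than the other three therefore stays open. Also open, from the compounds shown here alone, is whether another group at this place, such as a nitrile, a carboxylic acid or a longer alkyl chain, would give a number too.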